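A few compounds are considered here, and "the series" means these few. Any claim that something is new, unique, unknown or untested is made for them only; others in the source may bear on it.

The measured compounds and their numbers:

Compound 1, `CN1CCC2C(CCCC2NC(=O)c2ccccc2)C1`, gives 101 umol/kg in a functional assay on the whole organism (heart) with Mus musculus as the target; on this read-out higher numbers stand for an effect only at larger amounts of compound and lower numbers for an effect already at smaller amounts.
Compound 2, `CN1CCC2C(CCCC2NC(=O)c2ccc(Cl)cc2Cl)C1`, gives 88 umol/kg.
Compound 3, `CN1CCC2C(CCCC2NC(=O)c2ccc(C(F)(F)F)cc2)C1`, gives 48 umol/kg.

Compound 3 stands at the lowest of the three numbers, but its gap to compound 2 lies within the scatter, so no order between those two can be read. Going by the values given here, the one step that goes beyond the scatter is a 2.1-fold lower number from compound 1 to compound 3 (0.32 log units; beyond the scatter), a modest lowering brought by trifluoromethyl in place of hydrogen on an aromatic carbon.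

The unmeasured compound 4, `Cc1ccc(C(=O)NC2CCCC3CN(C)CCC32)cc1`, differs from compound 3 in one place: methyl in place of trifluoromethyl on an aromatic carbon. Among the compounds with values here, only that single measured step bears on this change, and it was modest. Methyl is the smaller group, and no step in this set tells how methyl itself behaves, so compound 4 is expected to land between compound 1 and compound 3, most likely with a small rise in the number. The step of a 1.5-fold higher number from compound 3 to compound 4 (0.16 log units; within the scatter) is the expected outcome. The estimate for compound 4 is 70 umol/kg, within a range from 35 umol/kg to 140 umol/kg.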

Compound 4, dose for half-maximal effect: 110 umol/kg
Compound 4: middle estimate off by 1.6-fold (0.20 log units), on the low side, and the stated range covers the measured number.
By their numbers in this assay, from the lowest: compounds 3, 2, 1 and 4 (each within the scatter of the next, the first and the last beyond it).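

At this place on the ring, para to a large group, the two groups are not interchangeable in this assay: methyl in place of trifluoromethyl gives a 2.3-fold higher number from compound 3 to compound 4 (0.36 log units; beyond the scatter). Methyl in place of hydrogen gives a 1.1-fold higher number from compound 1 to compound 4 (0.04 log units; within the scatter), so no effect of methyl can be read, and among these three compounds only trifluoromethyl shifts the number beyond the scatter. Nothing available explains why the two groups part in this way.

The compounds shown leave open whether the lower number is particular to trifluoromethyl or would also come with another group in the same place, such as a single chlorine, a nitrile or a methoxy group. They also leave open whether trifluoromethyl would give the same step on another carbon of the aromatic ring.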